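From morpholin-4-yl to 4-methylpiperazin-1-yl on the carbonyl carbon

The source may hold more compounds than are shown below. What is called first, only, known or untested is meant among the compounds shown, and "the series" means these compounds.

Of the compounds shown here, two have numbers so far in an ADME assay on MRC5 cells (Homo sapiens) for cytotoxicity, read by fluorescence and resazurin assay, with a stated time of 3 days; on this read-out lower numbers stand for an effect already at smaller amounts and higher numbers for an effect only at larger amounts of compound. Compound 1 `O=C1C=CC(O)(c2cc3ccccc3n2S(=O)(=O)c2ccc(CCCO)cc2)C=C1` gives 51 nM, and compound 2 `O=C1C=CC(O)(c2cc3ccccc3n2S(=O)(=O)c2ccc(CCC(=O)N3CCOCC3)cc2)C=C1` gives 67 nM. For the measured compounds named here, these two values lie within the scatter of each other, so compound 2 stands level with the only other measured compound. Going by the values given here, the single measured step is a 1.3-fold higher number from compound 1 to compound 2 (0.12 log units; within the scatter), with (morpholin-4-yl)carbonyl in place of hydroxymethyl on a saturated chain carbon, two bonds along the chain from an aromatic carbon.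

Compound 3 `CN1CCN(C(=O)CCc2ccc(S(=O)(=O)n3c(C4(O)C=CC(=O)C=C4)cc4ccccc43)cc2)CC1` keeps the shared core and carries 4-methylpiperazin-1-yl in place of morpholin-4-yl on a carbonyl carbon. Among the compounds with values here, no measured compound tests this exchange directly. Within the data shown here, the only guide is the change at the same chain end in compound 2, where a 1.3-fold higher number from compound 1 to compound 2 (0.12 log units; within the scatter) stayed within the scatter. No step beyond the scatter is therefore expected in this assay, and the expected step is a 1.1-fold lower number from compound 2 to compound 3 (0.05 log units; within the scatter). With one step to go on, the range is kept wide. For compound 3 the estimated value is 60 nM, with an expected range of 25 nM to 140 nM.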

Compound 3, half-maximal effective concentration: 52 nM
Beside the measured number, compound 3's estimate is 1.2-fold (0.06 log units) above it; measured number inside the range.
By their numbers in this assay, from the lowest: compounds 1, 3 and 2 (each within the scatter of the next).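

In this assay, the exchange on the carbonyl carbon can now be read directly: a 1.3-fold lower number from compound 2 to compound 3 (0.11 log units; within the scatter), so 4-methylpiperazin-1-yl in place of morpholin-4-yl does not separate the two amides in this read-out. The second new comparison, a 1.0-fold higher number from compound 1 to compound 3 (0.01 log units; within the scatter), gives (4-methylpiperazin-1-yl)carbonyl in place of hydroxymethyl a step within the scatter, as a 1.3-fold higher number from compound 1 to compound 2 (0.12 log units; within the scatter) did for (morpholin-4-yl)carbonyl, so all three chain ends shown stand level and a second amide now backs what a single step suggested. No separate measurement bears on why these compounds stand level.

The compounds shown leave open whether a carboxylic acid, a primary amine or a longer chain at this chain end would give a step beyond the scatter, as every change so far has stayed within it. They also leave open whether this level reading would hold with a fluorine on the shared core, and whether it extends to any read-out other than this assay.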